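The source may hold more compounds than are shown below. What is called first, only, known or untested is meant among the compounds shown, and "the series" means these compounds.

Measured so far:

Compound 1, `Nc1nc(N)c2nnn([C@H]3CCCC[C@H]3CO)c2n1`. In an ADME assay on L1210/0 cells (Mus musculus) for cytotoxicity, with a stated time of 48 h (a lower number here means a stronger inhibitor, a higher number a weaker inhibitor), compound 1 gives > 200000 nM, which is a limit of the assay and not a number.
Compound 2, `Nc1nc2c(nc(N)n2COCCO)c(=O)[nH]1`. In this assay compound 2 gives > 200000 nM, again a limit of the assay.
Compound 3, `Nc1nc2c(nc(O)n2COCCO)c(=O)[nH]1`. In this assay compound 3 gives > 200000 nM, also a limit of the assay.

The difference between the cores of compound 1 and compound 2 is not broken down here. Compound 2 and compound 3 share a core and differ in one place: hydroxy in place of amino on an aromatic carbon. The step that the two limits leave unreadable from compound 2 to compound 3 cannot be read, because of the limit of > 200000 nM in this assay, at which 3 of the 3 values shown sit.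

The compound not yet measured is compound 4, `Nc1nc(O)c2nnn([C@H]3CCCC[C@H]3CO)c2n1`. It differs from compound 1 by hydroxy in place of amino on an aromatic carbon. This is the same kind of change as that from compound 2 to compound 3, not the same change: in compound 2 the place is on a five-membered aromatic ring with 2 nitrogen, between two ring nitrogen atoms, next to the ring atom that bears a (2-hydroxyethoxy)methyl group, whereas in compound 1 it is on a six-membered aromatic ring with 2 nitrogen, next to the ring nitrogen, ortho to a fused ring, meta to a fused ring, meta to an amino group, opposite the ring nitrogen.

Within the data shown here, for compound 4 the step that the limit leaves unreadable from compound 1 to compound 4 is expected to be small, since compound 1 sits at > 200000 nM, a limit, and the only measured example of this kind of change, a step that the two limits leave unreadable from compound 2 to compound 3, gave nothing readable. Compound 4 is therefore estimated at 300000 nM, with a range from 80000 nM to 1000000 nM, most likely reported only as a limit.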

Compound 4, half-maximal inhibitory concentration: > 200000 nM
Compound 4: only a limit was reported; the forecaster's own chance of this, stated with the estimate: 85%; the middle value does not contradict the limit.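

No new step can be read between compound 1 and compound 4, the pair that differs by hydroxy in place of amino, because the result for compound 4 is again a limit of the assay and not a number: (the limit of > 200000 nM in this assay, at which 4 of the 4 values shown sit). The compounds shown leave open what size, if any, this change has in this assay on either core, and none of them offers a readable number for comparison.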